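A few compounds are considered here, and "the series" means these few. Any claim that something is new, unique, unknown or untested is made for them only; others in the source may bear on it.

Compound 1 `O=C(NO)c1ccc(CN(Cc2ccccc2)S(=O)(=O)c2c(F)c(F)c(F)c(F)c2F)cc1` and compound 2 `CN(C)c1ccc(CN(Cc2ccc(C(=O)NO)cc2)S(=O)(=O)c2c(F)c(F)c(F)c(F)c2F)cc1` share the same core and differ at a single aromatic carbon. In an assay on isolated protein for inhibition of histone deacetylase 11 (Homo sapiens), read by mobility shift assay (on this read-out higher numbers stand for weaker inhibition and lower numbers for stronger inhibition), compound 1 gives 122 nM. For compound 2 this assay reports only a limit, > 1000 nM, and no exact number. As far as these compounds go, the change from compound 1 to compound 2 brought an at least 8.1-fold higher number from compound 1 to compound 2 (0.91 log units; beyond the scatter), a step whose true size stays open because of the limit of > 1000 nM in this assay, at which 1 of the 2 values shown sits. Compound 3 `CC(C)(C)c1ccc(CN(Cc2ccc(C(=O)NO)cc2)S(=O)(=O)c2c(F)c(F)c(F)c(F)c2F)cc1` has not yet been measured; it carries tert-butyl in place of dimethylamino on an aromatic carbon. For the measured compounds named here, no measured pair shows what a tert-butyl group does in this position, so the only guide is the weakening seen when dimethylamino entered. On that basis compound 3 is expected to sit closer to compound 2 than to compound 1, with an estimated step of an at least 1.4-fold lower number from compound 2 to compound 3 (0.15 log units; that floor lies within the scatter) and an estimated value of 700 nM, within a range of 200 nM to 3000 nM.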

Compound 3, half-maximal inhibitory concentration: 88 nM
For compound 3 the middle estimate is 8.0-fold (0.90 log units) above the measured one, outside the stated range (below it).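

In this assay, the weakening seen with dimethylamino does not apply to every group at this position: swapping it for tert-butyl gives an at least 11-fold lower number from compound 2 to compound 3 (1.05 log units; beyond the scatter). Tert-butyl in place of hydrogen gives a 1.4-fold lower number from compound 1 to compound 3 (0.14 log units; within the scatter), so a group of this size can sit on this aromatic carbon without a measurable change from the unsubstituted compound. The full size of the swap from dimethylamino stays unknown because compound 2 is recorded only as a limit: the limit of > 1000 nM in this assay, at which 1 of the 3 values shown sits.

These compounds cannot show whether the loss in compound 2 follows from the nitrogen of dimethylamino or from some other feature of that group. An isopropyl group, a methoxy group, a primary amine or a carboxylic acid at this position would help to separate these possibilities.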